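Adding cyclopropylmethyl to the amino group of compound 1

This account rests on a few compounds, and the source may have more. Where it says the series, first, only, none or still open, it means among the compounds named here.

In a functional assay on HeLa cells (Homo sapiens) for antiproliferative activity, read by MTT assay, with a stated time of 48 h (on this read-out lower numbers stand for stronger inhibition and higher numbers for weaker inhibition), compound 1 (`Cn1cc(-c2cnc3ccnc(N)c3c2)cn1`) gives 40800 nM. Compound 3 (`Cn1cc(-c2cnc3ccc(NS(=O)(=O)c4cccs4)nc3c2)cn1`) gives 38400 nM, a value within the usual scatter of that of compound 1, so the two cannot be ranked. Compound 2 (`CC(=O)Nc1ccc2ncc(-c3cnn(C)c3)cc2n1`) returns only a limit of the assay, > 50000 nM.

Compound 4 (`Cn1cc(-c2cnc3ccnc(NCC4CC4)c3c2)cn1`) has not yet been measured. The change that leads to it is cyclopropylmethyl in place of hydrogen on a nitrogen on an aromatic ring, which turns amino into (cyclopropylmethyl)amino.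

Among the compounds with values here, only one measured step offers any guide: an at least 1.3-fold lower number from compound 2 to compound 3 (0.11 log units; that floor lies within the scatter). That step also exchanges a group on a nitrogen on an aromatic ring, but its floor lies within the scatter, the groups involved are different, and the core of compound 2 is not the core of compound 1. It therefore gives no sign of a large change in either direction. With nothing measured for cyclopropylmethyl itself, no step beyond the scatter is expected in this assay. The expected change is a 1.4-fold lower number from compound 1 to compound 4 (0.13 log units; within the scatter). For compound 4 the estimated value is 30000 nM, with an expected range from 12000 nM to 50000 nM.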

Compound 4, half-maximal inhibitory concentration: 7400 nM
Compound 4: the middle estimate sits 4.1-fold (0.61 log units) above what was measured, and the stated range ends above it.
By their numbers in this assay, from the lowest: compound 4; then compounds 3 and 1 (each within the scatter of the next). At a limit, above all of these: compound 2.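

In this assay, cyclopropylmethyl in place of hydrogen on a nitrogen on an aromatic ring gives a 5.5-fold lower number from compound 1 to compound 4 (0.74 log units; beyond the scatter), the only step among the compounds shown that lies beyond the scatter. The one earlier step, an at least 1.3-fold lower number from compound 2 to compound 3 (0.11 log units; that floor lies within the scatter), has a floor within the scatter and sits on a different core, so it could not show that a group on a nitrogen can move this read-out; the amino group of compound 1 is now shown to be such a place, and the change from amino to (cyclopropylmethyl)amino moves the number downward. The information given holds nothing that bears on why this step has its size, so the result stands as an observation on this one pair.

The compounds shown leave open whether the step belongs to the cyclopropylmethyl group in particular or would also appear with a plain methyl, a longer straight chain, a benzyl group or a chain ending in an amine on the same nitrogen. They also leave open whether cyclopropylmethyl would give a similar step on the core shared by compound 2 and compound 3.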